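The source may report more compounds than this note shows. Statements on the series, on what has been measured and on what is new or still open speak of the compounds shown alone.

Measured so far in a functional assay on OVCAR-3 cells (Homo sapiens) for inhibition, read by sulforhodamine B assay, with a stated time of 48 h; a higher number here means a weaker inhibitor, a lower number a stronger inhibitor:
compound 1 `O=C(Nc1cccc(-n2cc(-c3ccncc3)c(-c3cc(O)cc(Cl)c3)n2)c1)Nc1ccc(Cl)c(C(F)(F)F)c1`, 2340 nM;
compound 2 `O=C(Nc1cccc(-n2cc(-c3ccncc3)c(-c3cc(O)cc(Cl)c3)n2)c1)Nc1ccc(Cl)c(Cl)c1`, 1960 nM;
compound 3 `COc1cc(Cl)cc(-c2nn(-c3cccc(NC(=O)Nc4cc(C(F)(F)F)cc(C(F)(F)F)c4)c3)cc2-c2ccncc2)c1`, 330 nM.

Compound 3 gives the lowest number of the three, with compound 2 nearest and compound 1 furthest, both gaps beyond the scatter. Compound 4 `COc1cc(Cl)cc(-c2nn(-c3cccc(NC(=O)Nc4cccc(C(F)(F)F)c4)c3)cc2-c2ccncc2)c1` differs from compound 3 by hydrogen in place of trifluoromethyl on an aromatic carbon. Among the compounds with values here, the only measured step, a 1.2-fold lower number from compound 1 to compound 2 (0.08 log units; within the scatter), touches the same terminal ring but exchanges a trifluoromethyl for chloro rather than for hydrogen, so it offers no direct guide. With one trifluoromethyl removed from the ring that sets compound 3 apart, a modest rise in this assay is expected, a 2.0-fold higher number from compound 3 to compound 4 (0.29 log units; within the scatter). Compound 4 is estimated at 650 nM, range 250 nM to 1700 nM.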

Compound 4, half-maximal inhibitory concentration: 590 nM
Beside the measured number, compound 4's estimate is 1.1-fold (0.04 log units) above it, and the stated range covers the measured number.
By their numbers in this assay, from the lowest: compounds 3 and 4 (each within the scatter of the next); then compounds 2 and 1 (each within the scatter of the next).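

In this assay, hydrogen in place of trifluoromethyl on a six-membered aromatic ring of carbon only gives a 1.8-fold higher number from compound 3 to compound 4 (0.25 log units; within the scatter), so at this place the loss of one trifluoromethyl leaves a change within the scatter. Unlike the earlier step, which exchanged trifluoromethyl for chloro, this one removes the group and puts no other heavy atom there. No available evidence bears on the size of this step. Still open, as far as these compounds go, is whether a nitrile or an amine at this place would stay within the scatter of these values. Also open, from the compounds shown here alone, is whether hydrogen in place of the remaining trifluoromethyl would produce a change beyond the scatter.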